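Swapping One Ring on the Longer-Lived Compound

The source may hold more compounds than are shown below. What is called first, only, known or untested is meant among the compounds shown, and "the series" means these compounds.

In an ADME assay (liver, Mus musculus) for metabolic stability, using microsomes (on this read-out lower numbers stand for a shorter-lived compound and higher numbers for a longer-lived compound), compound 1 (`CCCc1nc2ccccn2c1C(=O)NCc1ccc(-c2ccccc2)cc1`) gives 0.145 h while compound 2 (`CCc1nc2cc(Cl)ccn2c1C(=O)NCc1ccc(-c2ccc(C)cc2)cc1`) gives 0.385 h as the higher of the two numbers, a gap beyond the usual scatter. Compound 3 (`CCc1nc2cc(Cl)ccn2c1C(=O)NCc1ccc(N2CCC(Cl)CC2)cc1`) alters compound 2 in one place, as 4-chloropiperidin-1-yl in place of 4-methylphenyl on an aromatic carbon shows, with 4-chloropiperidin-1-yl in place of 4-methylphenyl on an aromatic carbon. Among the measured compounds shown here, no measured pair shows a swap of this kind, so the expectation is loose, a small move towards a shorter life. The estimated step of a 1.5-fold lower number from compound 2 to compound 3 (0.19 log units; within the scatter) stays within the scatter. For compound 3 the expected half-life is 0.25 h with a likely range from 0.1 h to 0.6 h on repeated measurement.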

Compound 3, half-life: 0.0867 h
Estimate against measurement, compound 3: 2.9-fold (0.46 log units) above; the whole stated range lies above it.
By their numbers in this assay, from the lowest: compounds 3 and 1 (each within the scatter of the next); then compound 2.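

At this position, on an aromatic carbon of a six-membered aromatic ring of carbon only, the choice of ring matters: in this assay, 4-chloropiperidin-1-yl in place of 4-methylphenyl gives a 4.4-fold lower number from compound 2 to compound 3 (0.65 log units; beyond the scatter). The two groups have the same number of heavy atoms, so that count does not separate them, while the entering group brings a non-aromatic ring, a nitrogen and a chlorine. Nothing measured here explains the step.

The compounds shown leave open whether the non-aromatic ring or the chlorine accounts for the step. A plain piperidin-1-yl or a 4-chlorophenyl group in this place would pull the two apart.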